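A few compounds are considered here, and "the series" means these few. Any claim that something is new, unique, unknown or untested is made for them only; others in the source may bear on it.

Three hydroxamic acids have been tested in an assay on isolated protein for inhibition of protein deacetylase HDAC6 (Homo sapiens), read by fluorescence, with stated times of 10 min and 2 h; on this read-out higher numbers stand for weaker inhibition and lower numbers for stronger inhibition. Compound 1 `CN1CC(=O)N(Cc2ccc(C(=O)NO)cc2)C1=O` gives 119 nM; compound 2 `CC(C)(C)c1ccc(CN2CC(=O)N(Cc3ccc(C(=O)NO)cc3)C2=O)cc1` gives 40.7 nM; compound 3 `O=C(NO)c1ccc(CN2C(=O)NC(Cc3ccccc3)(c3ccccc3)C2=O)cc1` gives 71.9 nM. Compound 3 thus sits with its number between the other two, and both compound 1 and compound 2 lie within the usual scatter of it, so no order among the three can be claimed.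

Compound 4 `O=C(NO)c1ccc(CN2C(=O)NC(Cc3ccc4ccccc4c3)(c3ccccc3)C2=O)cc1` follows from compound 3 by one change: naphthalen-2-yl in place of phenyl on a saturated chain carbon bound to a saturated ring carbon. Among the compounds with values here, no measured pair shows this change, so any expectation rests on the three numbers alone. Because compound 2 gives 40.7 nM with its larger group, a modest move toward stronger inhibition is expected, though the step from compound 3 to compound 4 is estimated at a 1.4-fold lower number from compound 3 to compound 4 (0.16 log units; within the scatter), hardly beyond the scatter. Compound 4 is accordingly expected to give about 50 nM, within 20 nM to 150 nM.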

Compound 4, half-maximal inhibitory concentration: 74.6 nM
Estimate against measurement, compound 4: 1.5-fold (0.17 log units) below; low and high end bracket the measured number.
By their numbers in this assay, from the lowest: compounds 2, 3, 4 and 1 (each within the scatter of the next, the first and the last beyond it).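

In this assay, the step to the larger group is a 1.0-fold higher number from compound 3 to compound 4 (0.02 log units; within the scatter), so at this position a second six-membered aromatic ring of carbon only brings no change that can be told from the scatter. Size at this place, across phenyl and naphthalen-2-yl, therefore does not separate the two compounds on this read-out. Nothing available here offers an explanation for this result.

The compounds shown leave open whether an amine or a carboxylic acid on the benzyl group would also leave the number unchanged. They also leave open what a longer chain between that aromatic ring and the saturated ring carbon would do.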